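Benzimidazole in place of the hydrazone arm: compound 4

The source may report more compounds than this note shows. Statements on the series, on what has been measured and on what is new or still open speak of the compounds shown alone.

Measured so far in a functional assay, read by spectrophotometry, with a stated time of 1 h; on this read-out higher numbers stand for weaker inhibition and lower numbers for stronger inhibition:
- compound 1, `O=c1cc(/C=N\c2ccccc2O)c2c(OCc3ccccc3)cc(OCc3ccccc3)cc2o1`, gives 348000 nM
- compound 2, `O=c1cc(/C=N\Nc2ccc([N+](=O)[O-])cc2)c2ccc(OCc3ccccc3)cc2o1`, gives only a limit of the assay, > 2000000 nM
- compound 3, `O=c1cc(/C=N\Nc2ccccc2)c2ccc(OCc3ccccc3)cc2o1`, gives 455000 nM

Compound 3 holds the higher of the two numbers, with compound 1 nearest; the two lie within the scatter of each other, and no order between them is claimed. Compound 2 sits at a limit of the assay (the limit of > 2000000 nM in this assay, at which 1 of the 3 values shown sits). Among the measured compounds shown here, the single measured step, an at least 4.3-fold lower number from compound 2 to compound 3 (0.64 log units; beyond the scatter), concerns a substituent on the outer ring and leaves the rest of the molecule untouched.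

Compound 4, `O=c1cc(-c2nc3ccccc3[nH]2)c2ccc(OCc3ccccc3)cc2o1`, differs from compound 3 by a group of 9 heavy atoms (7 carbon, 2 nitrogen; one five-membered aromatic ring with 2 hetero atoms, one six-membered aromatic ring of carbon only) in place of a group of 9 heavy atoms (7 carbon, 2 nitrogen; one six-membered aromatic ring of carbon only), on an aromatic carbon. For the measured compounds named here, no measured step bears on this exchange: an at least 4.3-fold lower number from compound 2 to compound 3 (0.64 log units; beyond the scatter) alters a substituent on the same part of the molecule, not the part itself, and so gives no guide to size or direction here. With nothing to lean on, the expected step of a 1.1-fold lower number from compound 3 to compound 4 (0.06 log units; within the scatter) in this assay is set at none beyond the scatter, with a wide range to either side. Compound 4 is therefore estimated at 400000 nM in this assay, expected to fall between 80000 nM and 2000000 nM.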

Compound 4, half-maximal inhibitory concentration: "not active" (no number reported)
Compound 4: no number reported, so the estimate cannot be set against anything.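

In this assay, among the compounds shown here, compound 4 is recorded as "not active" with no number, so no step from compound 3 to compound 4 can be read. The size of any change on exchanging the hydrazone arm for 1H-benzimidazol-2-yl stays open, as does the standing of compound 4 against compound 2, whose value is a limit: the limit of > 2000000 nM in this assay, at which 1 of the 4 values shown sits.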